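Nitro for fluoro on the urea aryl ring of compound 3

The source may report more compounds than this note shows. Statements on the series, on what has been measured and on what is new or still open speak of the compounds shown alone.

Compound 1 `O=C(Nc1ccc(F)cc1)Nc1nc(-c2cc3cc(Br)ccc3o2)cs1` gives > 200000 nM in a physicochemical assay, with a stated time of 6 min (on this read-out higher numbers stand for weaker inhibition and lower numbers for stronger inhibition), which is a limit of the assay. Compound 2 `O=C(Nc1cccc([N+](=O)[O-])c1)Nc1nc(-c2cc3cc(Br)ccc3o2)cs1` gives 159000 nM. Compound 3 `O=C(Nc1nc(-c2cc3cc(Br)ccc3o2)cs1)Nc1ccccc1F` gives > 200000 nM, again only a limit.

Compound 3 therefore stands at the limit shared with compound 1 (the limit of > 200000 nM in this assay, at which 2 of the 3 values shown sit), while compound 2 alone returns a number. Compound 4 `O=C(Nc1nc(-c2cc3cc(Br)ccc3o2)cs1)Nc1ccccc1[N+](=O)[O-]` differs from compound 3 by nitro in place of fluoro on an aromatic carbon. The nearest measured guide is the nitro-for-fluoro change an at least 1.2-fold lower number from compound 1 to compound 2 (0.09 log units; that floor lies within the scatter), which turned a limit into a number; the reverse reading an at least 1.2-fold higher number from compound 2 to compound 3 (0.09 log units; that floor lies within the scatter) points the same way. A step like an at least 1.1-fold lower number from compound 3 to compound 4 (0.07 log units; that floor lies within the scatter) is expected, and compound 4 is estimated at 170000 nM with a range of 80000 nM to 300000 nM.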

Compound 4, half-maximal inhibitory concentration: 166000 nM
Beside the measured number, compound 4's estimate is 1.0-fold (0.01 log units) above it; measured number inside the range.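

In this assay compound 3 gives only a limit, while nitro in place of fluoro, ortho to a large group, returns a readable number, with an at least 1.2-fold lower number from compound 3 to compound 4 (0.08 log units; that floor lies within the scatter). The comparison with the other fluoro compound reads the same way, with an at least 1.2-fold lower number from compound 1 to compound 4 (0.08 log units; that floor lies within the scatter). The two nitro isomers cannot be told apart, with a 1.0-fold higher number from compound 2 to compound 4 (0.02 log units; within the scatter).

On these data alone, both fluoro steps are only floors, so the true size of the nitro-for-fluoro change stays open. Also open, as far as these compounds go, is whether an amine or a carboxylic acid at this ortho place would give a clearly lower number.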